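This account rests on a few compounds, and the source may have more. Where it says the series, first, only, none or still open, it means among the compounds named here.

Three compounds share one core, differing only in the aromatic group set on the carbon ring ortho to the seven-heavy-atom group. Compound 1 `c1ccc(-c2cnccn2)c(OCC2=NCCN2)c1` carries pyrazin-2-yl, compound 2 `c1csc(-c2ccccc2OCC2=NCCN2)c1` thiophen-2-yl, and compound 3 `c1c[nH]c(-c2ccccc2OCC2=NCCN2)c1` 1H-pyrrol-2-yl. In a functional assay with Alpha-1A adrenergic receptor (Homo sapiens) as the target, read by calcium flux (on this read-out higher numbers stand for larger maximal responses and lower numbers for smaller maximal responses), compound 1 gives 97%, compound 2 gives 101%, and compound 3 gives 99%. Compound 3 thus holds the second highest of the three numbers, but its nearest neighbour is compound 1, a number 2 percentage points higher from compound 1 to compound 3 (within the scatter), and the furthest is compound 2, a number 2 percentage points lower from compound 2 to compound 3 (within the scatter); all three sit within the scatter of one another, as does a number 4 percentage points higher from compound 1 to compound 2 (within the scatter).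

Compound 4 `c1ccc(-c2ccsc2)c(OCC2=NCCN2)c1` is not yet measured. Relative to compound 3 the change is thiophen-3-yl in place of 1H-pyrrol-2-yl on an aromatic carbon. The step most like it is the exchange of the five-membered group between compound 2 and compound 3, a number 2 percentage points lower from compound 2 to compound 3 (within the scatter), and the other exchanges of this group were no larger. Compound 4 is therefore expected to show no step beyond the scatter in this assay, a number 1 percentage points higher from compound 3 to compound 4 (within the scatter). Compound 4 is estimated at 100%, within 90% to 110%.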

Compound 4, largest response reached (reported as maximum), in percent of the reference or control that the assay uses: 98%
Estimate against measurement, compound 4: 2 percentage points above; low and high end bracket the measured number.
By their numbers in this assay, from the lowest: compounds 1, 4, 3 and 2 (each within the scatter of the next).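

In this assay, among the compounds shown here, thiophen-3-yl in place of thiophen-2-yl tests the attachment point of the same ring for the first time and gives a number 3 percentage points lower from compound 2 to compound 4 (within the scatter), so this change of attachment leaves no step beyond the scatter. The exchange of 1H-pyrrol-2-yl, with its hydrogen-bond donor, for thiophen-3-yl, with no donor and a hydrogen-bond acceptor, gives a number 1 percentage points lower from compound 3 to compound 4 (within the scatter), and the exchange of pyrazin-2-yl for thiophen-3-yl gives a number 1 percentage points higher from compound 1 to compound 4 (within the scatter), so these differences in donor and acceptor count also come with no step beyond the scatter on this aromatic carbon, ortho to a group of 7 heavy atoms. Nothing available explains why these exchanges leave the maximal response within the scatter.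

From the compounds shown here alone, whether an amine, a carboxylic acid or a longer chain on this aromatic carbon would keep the maximal response within the scatter remains open. The compounds shown also leave open what a change elsewhere on the shared core would do.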